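A chloro added to the phenyl of compound 1

This account rests on a few compounds, and the source may have more. Where it says the series, first, only, none or still open, it means among the compounds named here.

Of the compounds shown here, three have been measured so far in a functional assay on EC9706 cells (Homo sapiens) for antiproliferative activity, read by MTT assay, with a stated time of 72 h; on this read-out lower numbers stand for stronger inhibition and higher numbers for weaker inhibition. Compound 1, with the structure `O=C1CC2(CO1)CSC(=S)N2c1ccccc1`, gives 128000 nM and is the highest of the three numbers, the one showing the weakest inhibition. Compound 2, with the structure `CN1CCN(C(=S)SCC2=CC(=O)OC2)CC1`, gives 35800 nM in this assay, and compound 3, with the structure `CN(C)C(=S)SCC1=CC(=O)OC1`, gives 7550 nM in this assay. Both of those numbers lie beyond the usual scatter below compound 1.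

Compound 4, with the structure `O=C1CC2(CO1)CSC(=S)N2c1ccc(Cl)cc1`, is not yet measured. It differs from compound 1 in one place: chloro in place of hydrogen on an aromatic carbon, para to a large group. For the measured compounds named here, no measured pair shows this change, so there is no direct guide to its size. Compound 1 is expected to move only modestly, and in this assay the step of a 1.8-fold lower number from compound 1 to compound 4 (0.26 log units; within the scatter) is expected, a slight drop in the number that could still fall within the scatter. The value for compound 4 in this assay is estimated at 70000 nM, with a range from 25000 nM to 200000 nM.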

Compound 4, half-maximal inhibitory concentration: 32600 nM
The estimate for compound 4 lay 2.1-fold (0.33 log units) above the measured number, within the range that was stated.
By their numbers in this assay, from the lowest: compound 3; then compounds 4 and 2 (each within the scatter of the next); then compound 1.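

In this assay, chloro in place of hydrogen on an aromatic carbon, para to a large group, gives a 3.9-fold lower number from compound 1 to compound 4 (0.59 log units; beyond the scatter), a step beyond the usual scatter. For the compounds shown here, this is the first pair here that differs in only one place, so it is the first direct reading of what a change on this ring does. It shows that this position is not silent: a single added chlorine atom, with the rest of compound 1 unchanged, is enough to lower the number. Nothing measured here bears on why the number fell.

As far as these compounds go, it remains open whether this drop is specific to chloro or would also appear with fluoro, bromo, methyl or an amine at the same place. Also open, from the compounds shown here alone, is whether chloro elsewhere on the ring would have a similar effect.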